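This account rests on a few compounds, and the source may have more. Where it says the series, first, only, none or still open, it means among the compounds named here.

Working notes on the series. In a functional assay on 786-0 cells (Homo sapiens) for inhibition, read by sulforhodamine B assay, with a stated time of 48 h (a lower number here means a stronger inhibitor of growth, a higher number a weaker inhibitor of growth), compound 1 `CCOC(=O)C1=C(C)NC(=O)NC1c1ccc(SC)cc1` gives 2.5 ug/mL. Going by the values given here, compound 2 `CCOC(=O)C1=C(C)NC(=S)NC1C1CCCCC1`, the only other compound measured so far, gives 4.2 ug/mL. These two values lie within the usual scatter of each other, so compound 1 stands level with compound 2 and no ranking follows from them.

The unmeasured compound 3 `CCOC(=O)C1=C(C)NC(=O)NC1c1ccc(O)cc1` keeps the core of compound 1 and carries hydroxy in place of methylsulfanyl on an aromatic carbon, para to a large group: hydroxy in place of methylsulfanyl on an aromatic carbon. Among the compounds with values here, no two measured compounds differ in one place only, so the data give no direct measure of this change. The expectation therefore rests on compound 1 at 2.5 ug/mL, which shares everything with compound 3 except this one group. A modest rise in the number in this assay, toward weaker growth inhibition, is expected, as an estimated 2.4-fold higher number from compound 1 to compound 3 (0.38 log units; beyond the scatter), and a result within the scatter would remain plausible. For compound 3 the estimated value is 6 ug/mL, with an expected range of 1.5 ug/mL to 25 ug/mL.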

Compound 3, concentration for 50% growth inhibition: 25.8 ug/mL
Beside the measured number, compound 3's estimate is 4.3-fold (0.63 log units) below it; the measured number lies above the stated range.
By their numbers in this assay, from the lowest: compounds 1 and 2 (each within the scatter of the next); then compound 3.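

In this assay, going by these compounds alone, hydroxy in place of methylsulfanyl on an aromatic carbon, para to a large group, gives a 10-fold higher number from compound 1 to compound 3 (1.01 log units; beyond the scatter) and is the first single change that can be read directly. It shows that this position is not indifferent to the group it carries: an exchange of methylsulfanyl, with 2 heavy atoms and no hydrogen-bond donor, for hydroxy, with 1 heavy atom and 1 hydrogen-bond donor, moves the number well beyond the scatter, toward weaker growth inhibition. No measurement at hand bears on why the number moves in this way.

One pair cannot show which part of the exchange carries the step, the loss of sulfur, the loss of the methyl carbon or the gain of the hydroxy hydrogen. As far as these compounds go, whether methoxy, chlorine or an amine at the same place would stay close to compound 1 or lie closer to compound 3 remains open, as does whether the same exchange would give a step of this size on another core.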